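Removal of the iodo substituent from compound 2

The compounds below may be only part of what the source reports. "The series", "measured", "known", "first", "only" and "open" are said of these compounds alone.

Of the compounds shown here, three have been measured in an assay on HEK293 cells with Neuronal acetylcholine receptor; alpha4/beta2 (Homo sapiens) as the target, read by FLIPR and calcium flux; on this read-out higher numbers stand for larger maximal responses and lower numbers for smaller maximal responses. Compound 1 `C=COc1cncc(N2CCNCC2)c1` gives 18%; compound 2 `Oc1cc(N2CCCNCC2)cnc1I` gives 104%; compound 3 `Brc1ccc(N2CCNCC2)cn1` gives 129%. On these numbers compound 2 stands second highest of the three: compound 3 lies above it by a margin beyond the scatter, and compound 1 lies far below it, also beyond the scatter. No two of the measured compounds differ in only one place, so no single step can be read from the data.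

Compound 4 `Oc1cncc(N2CCCNCC2)c1` has not been measured. It differs from compound 2 as follows: hydrogen in place of iodo on an aromatic carbon. The iodo group leaves and a hydrogen atom takes its position next to the ring nitrogen, ortho to the hydroxy group.

Within the data shown here, both compounds with a large maximal response carry a halogen; the single compound without one, compound 1, responds weakly, but it differs in several places, so no pattern is claimed. The step in this assay from compound 2 to compound 4 is expected to be modest, most likely downward, and perhaps within the scatter: a number 14 percentage points lower from compound 2 to compound 4 (beyond the scatter). Compound 4 is estimated to give 90%, within a range from 50% to 130%.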

Compound 4, largest response reached (reported as efficacy), in percent of the reference or control that the assay uses: 120%
For compound 4 the middle estimate is 30 percentage points below the measured one; low and high end bracket the measured number.
By their numbers in this assay, from the lowest: compound 1; then compound 2; then compounds 4 and 3 (each within the scatter of the next).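

In this assay, among these compounds, hydrogen in place of iodo on the aromatic carbon next to the ring nitrogen gives a number 16 percentage points higher from compound 2 to compound 4 (beyond the scatter), the first step that can be read at a single position. The iodo group is therefore not required for a large maximal response on this scaffold: compound 4, which carries no halogen, reaches 120%, and the change raises the response modestly rather than lowering it. Nothing available on this change explains the size or direction of the step.

Still open, as far as these compounds go, is how fluoro, chloro, methyl or an amine on the same aromatic carbon would compare with iodo and hydrogen. Also open, from the compounds shown here alone, is whether a methoxy group in place of the hydroxy group would keep the response of compound 4, and whether this step carries over to other cores.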